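A few compounds are considered here, and "the series" means these few. Any claim that something is new, unique, unknown or untested is made for them only; others in the source may bear on it.

Working notes on the series. Compound 2 `Nc1ccc(S(=O)(=O)N2CCN(c3ncc(C(O)(C(F)(F)F)C(F)(F)F)cc3C#CCO)CC2)cn1` is the point of departure. Going by the values given here, in an ADME assay (liver) for metabolic stability, with Liver microsome (Rattus norvegicus) as the target, using microsomes and NADPH, with a stated time of 30 min, tested at 1 uM (a lower number here means slower removal, a higher number faster removal of the compound), compound 2 gives 65 mL.min-1.g-1, the second highest of the three numbers so far. Compound 1 `Nc1ccc(S(=O)(=O)N2CCN(c3ncc(C(O)(C(F)(F)F)C(F)(F)F)cc3C#CC3CC3)CC2)cn1` gives 67 mL.min-1.g-1, and the step of a 1.0-fold lower number from compound 1 to compound 2 (0.01 log units; within the scatter) is within the scatter, so no order between compounds 1 and 2 is claimed. Compound 3 `CC(C)(O)C#Cc1cc(C(O)(C(F)(F)F)C(F)(F)F)cnc1N1CCN(S(=O)(=O)c2ccc(N)nc2)CC1` gives 16 mL.min-1.g-1, the furthest from compound 2; the step of a 4.1-fold lower number from compound 2 to compound 3 (0.61 log units; beyond the scatter) is modest, as is the parallel step a 4.2-fold lower number from compound 1 to compound 3 (0.62 log units; beyond the scatter).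

Compound 4 `Nc1ccc(S(=O)(=O)N2CCN(c3ncc(C(O)(C(F)(F)F)C(F)(F)F)cc3-c3ccccc3O)CC2)cn1` is not yet measured. The change from compound 2 is 2-hydroxyphenyl in place of 3-hydroxyprop-1-yn-1-yl on an aromatic carbon. Among the compounds with values here, none of the measured steps bears directly on it: all three keep the triple-bonded carbon and vary only what sits on it, whereas here the whole 3-hydroxyprop-1-yn-1-yl group is exchanged for a 2-hydroxyphenyl group. The measured steps that exchange one group on the triple-bonded carbon for another span from within the scatter up to modest, so a change of at most modest size in this assay is expected, with no direction supported by the data. Compound 4 is therefore expected to give about 60 mL.min-1.g-1, within the range 25 mL.min-1.g-1 to 140 mL.min-1.g-1, which amounts to an expected step of a 1.1-fold lower number from compound 2 to compound 4 (0.03 log units; within the scatter).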

Compound 4, intrinsic clearance in microsomes: 125 mL.min-1.g-1
Compound 4: middle estimate off by 2.1-fold (0.32 log units), on the low side; the measured number falls inside the stated range.
By their numbers in this assay, from the lowest: compound 3; then compounds 2, 1 and 4 (each within the scatter of the next).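

In this assay, exchanging the whole group on the aromatic carbon leaves the number within the scatter, a 1.9-fold higher number from compound 2 to compound 4 (0.28 log units; within the scatter) and a 1.9-fold higher number from compound 1 to compound 4 (0.27 log units; within the scatter), so at this position the triple bond is not required for a number in the range of compounds 1 and 2. Compound 3 stays apart, a 7.8-fold higher number from compound 3 to compound 4 (0.89 log units; beyond the scatter), and among the four compounds only its 3-hydroxy-3-methylbut-1-yn-1-yl group goes with a lower number, while the hydroxyl-bearing groups of compound 2 and compound 4 do not. Nothing available explains this difference.

Still open, on these data alone, is whether a plain phenyl, 2-methoxyphenyl or 2-aminophenyl group at this place would give a number like that of compound 4. Also open, as far as these compounds go, is whether the lower number of compound 3 extends to other tertiary alcohols on the triple-bonded carbon.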